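From 4-chlorophenyl to naphthalen-1-yl on a shared core

A few compounds are considered here, and "the series" means these few. Any claim that something is new, unique, unknown or untested is made for them only; others in the source may bear on it.

Of the compounds shown here, three with a shared core have been measured in a functional assay (aorta) with Oryctolagus cuniculus as the target; on this read-out higher numbers stand for weaker binding and lower numbers for tighter binding. Compound 1 (`CCc1ccc(OCCCN2CCC(C(c3ccc(F)cc3)c3ccc(F)cc3)CC2)c(OC)c1`) gives 2.51 nM, compound 2 (`Fc1ccc(OCCCN2CCC(C(c3ccc(F)cc3)c3ccc(F)cc3)CC2)cc1`) gives 1.26 nM, and compound 3 (`Fc1ccc(C(c2ccc(F)cc2)C2CCN(CCCOc3ccc(Cl)cc3)CC2)cc1`) gives 2 nM. Compound 3 therefore stands with the other two, all within the usual scatter of repeated measurements. The next compound, compound 4 (`Fc1ccc(C(c2ccc(F)cc2)C2CCN(CCCOc3cccc4ccccc34)CC2)cc1`), has naphthalen-1-yl in place of 4-chlorophenyl on an oxygen on a saturated carbon.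

The measured steps that bear on this change alter the same group. They are a 2.0-fold lower number from compound 1 to compound 2 (0.30 log units; within the scatter), a 1.3-fold lower number from compound 1 to compound 3 (0.10 log units; within the scatter) and a 1.6-fold higher number from compound 2 to compound 3 (0.20 log units; within the scatter). None of them brings in naphthalen-1-yl, so this evidence is only indirect. Even so, no shift beyond the scatter is expected in this assay, and the expected size is a 1.3-fold higher number from compound 3 to compound 4 (0.10 log units; within the scatter). Compound 4 is estimated at 2.5 nM, with an expected range of 1 nM to 6 nM.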

Compound 4, dissociation constant: 5.01 nM
The estimate for compound 4 lay 2.0-fold (0.30 log units) below the measured number, and the stated range covers the measured number.
By their numbers in this assay, from the lowest: compounds 2, 3, 1 and 4 (each within the scatter of the next, the first and the last beyond it).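

In this assay, among the compounds shown here, naphthalen-1-yl is the only group on this oxygen whose change from another group here goes beyond the scatter, with the number rising against both smaller halogenated phenyl groups (a 2.5-fold higher number from compound 3 to compound 4 (0.40 log units; beyond the scatter); a 4.0-fold higher number from compound 2 to compound 4 (0.60 log units; beyond the scatter)). Compound 1 goes against any simple rule, as its 4-ethyl-2-methoxyphenyl group cannot be told apart from naphthalen-1-yl (a 2.0-fold higher number from compound 1 to compound 4 (0.30 log units; within the scatter)), so the position accepts a second six-membered aromatic ring with only a modest loss at most. Nothing available explains the shift.

With a single two-ring group, the shift cannot be tied to either ring in particular. From the compounds shown here alone, it also remains open how a pyridine ring, or a phenyl ring carrying an amine or a carboxylic acid, would read in this place.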